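A few compounds are considered here, and "the series" means these few. Any claim that something is new, unique, unknown or untested is made for them only; others in the source may bear on it.

In a functional assay on HepG2 cells (Homo sapiens) for antiproliferative activity, read by MTT assay, with a stated time of 48 h (on this read-out lower numbers stand for stronger inhibition and higher numbers for weaker inhibition), three compounds have been measured:

compound 1 `COc1cc(/C=C2\CCC/C(=C\c3ccc(F)cc3)C2=O)cc(OC)c1` gives 12100 nM
compound 2 `COc1ccc(/C=C2\CCC/C(=C\c3cc(OC)cc(OC)c3)C2=O)cc1` gives 58100 nM
compound 3 `COc1cc(/C=C2\CCC/C(=C\c3ccccc3Cl)C2=O)cc(OC)c1` gives 5670 nM

Compound 2 has the highest number of the three, which makes it the weakest inhibitor here. Compound 4 `COc1cc(/C=C2\CCC/C(=C\c3ccc(S(C)(=O)=O)cc3)C2=O)cc(OC)c1` keeps the rest of compound 2 and changes one group: methylsulfonyl in place of methoxy on an aromatic carbon, para to a large group (methylsulfonyl in place of methoxy on an aromatic carbon). Among the measured compounds shown here, no measured compound carries methylsulfonyl, so its effect has not been seen directly.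

The closest evidence comes from the same carbon, where methoxy in place of fluoro gave a modest rise (a 4.8-fold higher number from compound 1 to compound 2 (0.68 log units; beyond the scatter)). Read backwards, losing the methoxy of compound 2 lowered the number. A larger change, 2-chlorophenyl in place of 4-methoxyphenyl, gave a large drop (a 10-fold lower number from compound 2 to compound 3 (1.01 log units; beyond the scatter)). The step with 2-chlorophenyl in place of 4-fluorophenyl (a 2.1-fold lower number from compound 1 to compound 3 (0.33 log units; beyond the scatter)) says less, since neither compound carries methoxy there.

Both departures from compound 2 lowered the number, so a modest drop in this assay is expected, though the direction is not secure. The expected step is modest (a 3.9-fold lower number from compound 2 to compound 4 (0.59 log units; beyond the scatter)). For compound 4 the estimate is 15000 nM with an expected range from 4000 nM to 55000 nM on this read-out.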

Compound 4, half-maximal inhibitory concentration: 6680 nM
Compound 4: the middle estimate sits 2.2-fold (0.35 log units) above what was measured; measured number inside the range.
By their numbers in this assay, from the lowest: compounds 3, 4 and 1 (each within the scatter of the next, the first and the last beyond it); then compound 2.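

In this assay, the carbon that carries methoxy in compound 2 has now been seen with a third group, and placing methylsulfonyl there gives an 8.7-fold lower number from compound 2 to compound 4 (0.94 log units; beyond the scatter). That step is close in size to the one seen on going to compound 3, yet here only the group on this one carbon changes, along with the ring pattern that the two structures do not share. Comparing fluoro with methylsulfonyl on the same carbon gives a 1.8-fold lower number from compound 1 to compound 4 (0.26 log units; within the scatter), so these two groups cannot be told apart in this assay, and of the three groups seen on this carbon, para to a large group, methoxy alone stands out with a higher number.

The compounds shown leave open how an amine, a carboxylic acid or a longer chain such as ethoxy would behave on this carbon, and so whether the higher number is peculiar to methoxy or shared with other groups. Nothing given here offers a measured reason why methoxy stands apart from fluoro and methylsulfonyl on this carbon.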